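Moving the Halogen on the Sulfonamide Ring of Compound 2

The source may hold more compounds than are shown below. What is called first, only, known or untested is meant among the compounds shown, and "the series" means these compounds.

Compound 1 `CC(=O)c1ccc(OCCCN2CC[C@H](NC(=O)[C@@H](N)CO)C2)cc1`, compound 2 `O=C(c1ccc(OCCCN2CC[C@H](NS(=O)(=O)c3ccc(Br)cc3)C2)cc1)C1CC1` and compound 3 `CC(=O)c1ccc(OCCCN2CC[C@H](NC(=O)c3csc(-c4cccnc4)n3)C2)cc1` share one core and differ only in the group carried on the amine of that core. In an assay on isolated protein for binding affinity to histamine H2 receptor (Homo sapiens) (a lower number here means a stronger inhibitor, a higher number a weaker inhibitor), compound 1 gives 22000 nM, compound 3 gives 6200 nM and compound 2 gives 290 nM. Compound 2 thus shows the lowest number of the three and is the strongest binder among them, since its gaps to compound 3 and to compound 1 both lie beyond the usual scatter of this assay.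

Compound 4 `O=C(c1ccc(OCCCN2CC[C@H](NS(=O)(=O)c3cccc(Cl)c3)C2)cc1)C1CC1` has not yet been measured. It differs from compound 2 in a single place: 3-chlorophenyl in place of 4-bromophenyl on a sulfonyl sulfur. Nothing counted in the two groups changes; one halogenated phenyl ring is exchanged for another, with the halogen type and its position on the ring being the only differences.

Among the measured compounds shown here, no measured pair shows this kind of exchange, so the expectation rests on the change being small. Compound 4 is expected to stay close to compound 2, with a step of a 1.6-fold higher number from compound 2 to compound 4 (0.19 log units; within the scatter) that may well remain within the scatter, leaning if anything toward a slightly weaker result. The estimate for compound 4 in this assay is 450 nM, with a likely range from 150 nM to 1500 nM.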

Compound 4, inhibition constant: 700 nM
Beside the measured number, compound 4's estimate is 1.6-fold (0.19 log units) below it, within the range that was stated.
By their numbers in this assay, from the lowest: compound 2; then compound 4; then compound 3; then compound 1.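

Among the compounds shown here, exchanging 4-bromophenyl for 3-chlorophenyl on a sulfonyl sulfur gives a 2.4-fold higher number from compound 2 to compound 4 (0.38 log units; beyond the scatter) in this assay, and this is the first pair that differs in one place only. For the compounds shown here, the earlier compounds differ from one another in more than this single group, so this pair gives the first direct reading of what a change at this position does: a modest loss of binding, even though the two groups have the same count of heavy atoms and neither carries a hydrogen-bond donor or acceptor. The halogen and its position on the ring change together in this one step, and nothing shown here indicates what lies behind the step.

The pair therefore leaves open how much of the step belongs to the exchange of bromine for chlorine and how much to the new position of the halogen on the ring. It also leaves open how binding would respond if a plain phenyl ring, or a ring carrying a methoxy group, a nitrile or an amine instead of a halogen, stood on the sulfonyl sulfur.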